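A few compounds are considered here, and "the series" means these few. Any claim that something is new, unique, unknown or untested is made for them only; others in the source may bear on it.

Measured in a functional assay on J774.A1 cells (Mus musculus) for inhibition, read by immunoassay, with a stated time of 12 h, tested at 30 uM; a higher number here means more inhibition at the concentration tested (going by the name of the read-out), a lower number less inhibition:
compound 1 `C=CCOc1ccccc1C1CC(=O)c2ccccc2O1` gives 47%
compound 2 `CC(C)COc1ccccc1C1CC(=O)c2ccccc2O1` gives 33.5%
compound 3 `COc1ccccc1C1CC(=O)c2ccccc2O1` gives 38.3%

Compound 3 holds the second highest of the three numbers in this assay, but the steps of a number 4.8 percentage points higher from compound 2 to compound 3 (within the scatter) and a number 8.7 percentage points lower from compound 1 to compound 3 (within the scatter) both lie within the scatter, so no real order can be read among these three. Compound 4 `CCCCOc1ccccc1C1CC(=O)c2ccccc2O1` differs from compound 3 by propyl in place of hydrogen on a saturated chain carbon bound to an oxygen on an aromatic ring. Within the data shown here, the steps that bear on this exchange at the same saturated chain carbon bound to an oxygen on the aromatic ring are a number 4.8 percentage points higher from compound 2 to compound 3 (within the scatter) and a number 8.7 percentage points lower from compound 1 to compound 3 (within the scatter), neither beyond the scatter; the single step beyond it, a number 13.5 percentage points lower from compound 1 to compound 2 (beyond the scatter), sets vinyl against isopropyl and does not involve hydrogen. Putting propyl onto compound 3 is thus expected to give no step beyond the scatter in this assay, an expected step of a number 1.3 percentage points lower from compound 3 to compound 4 (within the scatter). Compound 4 is estimated at 37%, in the range 25% to 49%.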

Compound 4, a percentage reported as inhibition, at one concentration (the size of the read-out at that concentration, not a potency): 42.5%
The estimate for compound 4 lay 5.5 percentage points below the measured number; the measured number falls inside the stated range.
By their numbers in this assay, from the lowest: compounds 2, 3, 4 and 1 (each within the scatter of the next, the first and the last beyond it).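

In this assay propyl in place of hydrogen on a saturated chain carbon bound to an oxygen on an aromatic ring gives a number 4.2 percentage points higher from compound 3 to compound 4 (within the scatter) so methoxy to butoxy brings no readable change. Compound 4 also stays unseparated from the other two ethers, with a number 9 percentage points higher from compound 2 to compound 4 (within the scatter) and a number 4.5 percentage points lower from compound 1 to compound 4 (within the scatter) as its steps to them. On these data alone, whether a longer chain, or an amine or a carboxylic acid carried on the chain, would give a step beyond the scatter stays open. No supporting data bear on these numbers.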